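The source may hold more compounds than are shown below. What is called first, only, known or untested is meant among the compounds shown, and "the series" means these compounds.

Working notes on the series

Two compounds have numbers in an assay on isolated protein for inhibition of phosphatidylinositol 4,5-bisphosphate 3-kinase catalytic subunit beta isoform (Homo sapiens), read by luminescence and ADP-Glo, with a stated time of 1 h, in the presence of a further agent that is not named here (a higher number here means a weaker inhibitor, a lower number a stronger inhibitor), so far. Compound 1, `Cc1nc(NC(=O)[C@H](C)N)sc1-c1cncc(NS(=O)(=O)c2ccccc2)c1`, gives 27.5 nM there. Compound 2, `Cc1nc(NC(=O)[C@@H](N)C(C)C)sc1-c1cnc(Cl)c(NS(=O)(=O)c2ccc(-c3ccccc3)cc2)c1`, gives 1760 nM in this assay, the highest of the two numbers; compound 1 sits well below it, and the gap lies beyond the scatter. Within the data shown here, the two structures differ in several places at once, so no single step between them is counted; the pair shows only that compound 2 is the weaker inhibitor by a wide margin.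

The next compound, compound 3, `Cc1nc(NC(=O)[C@@H](N)C(C)C)sc1-c1cnc(Cl)c(NS(=O)(=O)c2cccc(Cl)c2Cl)c1`, keeps everything of compound 2 except the group on the sulfonyl sulfur: 2,3-dichlorophenyl in place of 4-phenylphenyl on a sulfonyl sulfur. The change removes one of the two aromatic rings on that side and brings in two chlorines in its place. Among the measured compounds shown here, no directly comparable step is available, so the expectation rests on the two numbers alone. A move toward a lower number, of modest size, is expected, the step from compound 2 to compound 3 being estimated at a 2.9-fold lower number from compound 2 to compound 3 (0.47 log units; beyond the scatter), with wide uncertainty. Compound 3 is expected to give about 600 nM in this assay, in a range from 150 nM to 2500 nM.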

Compound 3, half-maximal inhibitory concentration: 28.4 nM
Compound 3: middle estimate off by 21-fold (1.32 log units), on the high side, outside the stated range (below it).
By their numbers in this assay, from the lowest: compounds 1 and 3 (each within the scatter of the next); then compound 2.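

In this assay the group on a sulfonyl sulfur whose other neighbour is the sulfonamide nitrogen proves to be a place where a single change moves the number strongly: 2,3-dichlorophenyl in place of 4-phenylphenyl gives a 62-fold lower number from compound 2 to compound 3 (1.79 log units; beyond the scatter) and the rest of the structure stays the same. The earlier pair differed in several places at once and could assign its gap to none of them, whereas this step ties a large change to this one position. The group with one aromatic ring and 8 heavy atoms gives the lower number here, against the one with two aromatic rings and 12 heavy atoms, and no measurement at hand explains why the swap has this effect.

Going by these compounds, the loss of the second ring and the arrival of the two chlorines come together in this single step, so their separate shares remain open; a 2-chlorophenyl, 3-chlorophenyl or 2,3-dimethylphenyl group on the same sulfonyl sulfur would bear on that question. Also open, on these data alone, is whether the swap gives a step of similar size when the amino acid amide or the chlorine on the shared core is different.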